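This account rests on a few compounds, and the source may have more. Where it says the series, first, only, none or still open, it means among the compounds named here.

Measured so far:
compound 1, `COc1ccc(/C=C2\c3cc(OC)c(OC)c(OC)c3CC[C@@H]2O)cc1[N+](=O)[O-]` — in a functional assay on HT-29 cells (Homo sapiens) for inhibition, read by MTT assay (a lower number here means a stronger inhibitor, a higher number a weaker inhibitor), compound 1 gives 1590 nM
compound 2, `COc1ccc(/C=C2\c3cc(OC)c(OC)c(OC)c3CC[C@@H]2O)cc1C` — compound 2 gives 2560 nM
compound 3, `COc1ccc(/C=C2\c3cc(OC)c(OC)c(OC)c3CC[C@H]2O)cc1[N+](=O)[O-]` — for compound 3 the reading is a limit of this assay, > 10000 nM

Compound 1 and compound 2 differ by methyl in place of nitro on an aromatic carbon; the step is a 1.6-fold higher number from compound 1 to compound 2 (0.21 log units; within the scatter). Compound 1 and compound 3 differ by the two compounds have the same atoms and bonds and differ only in configuration as drawn: 1 of 2 stereo elements differ; a stereocentre at a saturated ring carbon is drawn S in compound 1 and R in compound 3; the step is an at least 6.2-fold higher number from compound 1 to compound 3 (0.79 log units; beyond the scatter), read against the limit of > 10000 nM in this assay, at which 1 of the 3 values shown sits, and (the fact that compounds 1 and 3 differ only in the configuration as drawn).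

Compound 4, `COc1ccc(/C=C2\c3cc(OC)c(OC)c(OC)c3CC[C@H]2O)cc1C`, is not yet measured. It differs from compound 3 by methyl in place of nitro on an aromatic carbon, the same change as from compound 1 to compound 2. In this assay the expected step is a step that the limit leaves unreadable from compound 3 to compound 4, resting on a 1.6-fold higher number from compound 1 to compound 2 (0.21 log units; within the scatter) lying within the scatter. The reading of compound 3 is a limit, > 10000 nM. Compound 4 is therefore estimated at about 16000 nM, expected between 7000 nM and 40000 nM.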

Compound 4, half-maximal inhibitory concentration: 3970 nM
Beside the measured number, compound 4's estimate is 4.0-fold (0.61 log units) above it, outside the stated range (below it).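

Methyl in place of nitro gives an at least 2.5-fold lower number from compound 3 to compound 4 (0.40 log units; beyond the scatter) in this assay, which does not match the step for the same change on the other core: the same change on two cores in this assay, a 1.6-fold higher number (0.21 log units; within the scatter) from compound 1 to compound 2 and an at least 2.5-fold lower number (0.40 log units; beyond the scatter) from compound 3 to compound 4, at least 4.0-fold (0.60 log units) apart, beyond the scatter of two such steps. The reading of compound 3, > 10000 nM, is a limit of the assay and not a number. Among the methyl compounds, the opposite configuration at the saturated ring carbon gives a 1.6-fold higher number from compound 2 to compound 4 (0.19 log units; within the scatter), so the change cannot be carried as a fixed step between these two cores, which differ only in that configuration, but two cores do not show how it would behave on any other.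

The compounds shown leave open whether other groups in that place, such as an amine or a carboxylic acid, would follow nitro or methyl. They also leave open whether the two configurations would separate with such groups.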